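Dropping a Methoxy Group: Little Change Expected

The compounds below may be only part of what the source reports. "The series", "measured", "known", "first", "only" and "open" are said of these compounds alone.

Compound 2 `COc1cc(-c2cc(/C=C/C(=O)c3ccc(N)cc3)[nH]n2)cc(OC)c1OC` was tested in a functional assay on NCI-H226 cells (Homo sapiens) for cytotoxicity, read by sulforhodamine B assay, with a stated time of 48 h, tested at 0.01 uM (a higher number here means a weaker effect of the compound at the concentration tested, a lower number a stronger effect), and gave 92%. Among the measured compounds shown here, only one other compound has a number here: compound 1 `COc1ccc(-c2cc(/C=C/C(=O)c3ccc(N)cc3)[nH]n2)cc1`, which gave 102%; the gap between them lies within the usual scatter, so the two cannot be told apart. Compound 3 `COc1ccc(-c2cc(/C=C/C(=O)c3ccc(N)cc3)[nH]n2)cc1OC` awaits measurement; it differs from compound 2 by hydrogen in place of methoxy on an aromatic carbon. Because compound 2 gives 92% and compound 1 gives 102%, both showing almost no effect at this concentration, the step of a number 5 percentage points higher from compound 2 to compound 3 (within the scatter) is expected to stay within the scatter. Compound 3 is therefore estimated to give 97%, with a range from 85% to 108%.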

Compound 3, a percentage reported as activity, at one concentration (the size of the read-out at that concentration, not a potency): 93%
For compound 3 the middle estimate is 4 percentage points above the measured one; measured number inside the range.
By their numbers in this assay, from the lowest: compounds 2, 3 and 1 (each within the scatter of the next).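

Compound 3 now links two single changes in this assay: hydrogen in place of methoxy gives a number 1 percentage points higher from compound 2 to compound 3 (within the scatter), and methoxy in place of hydrogen gives a number 9 percentage points lower from compound 1 to compound 3 (within the scatter). Neither exchange can be told from the scatter, so at this one low concentration neither step shows a readable effect of a methoxy group. No evidence at hand bears on this result. From the compounds shown here alone, whether an amine or a hydroxyl group at this place would move the number stays open. So does whether these compounds differ at higher concentrations.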